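Imidazole to aminoimidazoline on the ethanesulfonamide series

The source may hold more compounds than are shown below. What is called first, only, known or untested is meant among the compounds shown, and "the series" means these compounds.

Compound 1 `O=S(=O)(Nc1cccc2c1CCCC2c1c[nH]cn1)c1ccc2ccccc2c1` gives 214 nM in an assay on isolated protein (Cricetulus griseus) for binding affinity to Alpha-1B adrenergic receptor (Mesocricetus auratus), read by radioligand binding; on this read-out higher numbers stand for weaker inhibition and lower numbers for stronger inhibition. Compound 2 `CCS(=O)(=O)Nc1cccc(-c2c[nH]cn2)c1` gives only a limit in this assay, < 10000 nM. That reading is the limit of < 10000 nM in this assay, at which 1 of the 2 values shown sits, so no number stands for compound 2. Compound 3 `CCS(=O)(=O)Nc1cccc(NC2=NCCN2)c1` differs from compound 2 in one place: a group of 6 heavy atoms (3 carbon, 3 nitrogen; one five-membered non-aromatic ring with 2 hetero atoms) in place of a group of 5 heavy atoms (3 carbon, 2 nitrogen; one five-membered aromatic ring with 2 hetero atoms), on an aromatic carbon. Among the compounds with values here, no step between two measured compounds covers this change, and the limit for compound 2 leaves no anchor for its size or direction. The step expected here is a step that the limit leaves unreadable from compound 2 to compound 3. Compound 3 is estimated at 3000 nM, with a range from 300 nM to 10000 nM.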

Compound 3, inhibition constant: < 10000 nM
Compound 3: no number, only a limit; the forecaster's own chance of this, stated with the estimate: 35%; the middle value does not contradict the limit.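

No step can be read from compound 2 to compound 3, since each gives only a limit in this assay: the limit of < 10000 nM in this assay, at which 2 of the 3 values shown sit.

Open remains how far, and in which direction, replacing 1H-imidazol-4-yl with the group in compound 3 moves the inhibition constant in this assay.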